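The source may hold more compounds than are shown below. What is called first, only, known or untested is meant among the compounds shown, and "the series" means these compounds.

Measured compounds:
compound 1 `Cc1[nH]n(-c2nc3cc(-c4ccccc4)ccc3[nH]2)c(=O)c1Cc1ccccc1` — 810 nM
compound 2 `Cc1[nH]n(-c2nc3c(C)cccc3[nH]2)c(=O)c1Cc1ccccc1` — 5900 nM
compound 3 `Cc1ccc2[nH]c(-n3[nH]c(C)c(Cc4ccccc4)c3=O)nc2c1C` — > 10000 nM

In an assay on isolated protein for inhibition of alpha-ketoglutarate-dependent dioxygenase alkB homolog 3 (Homo sapiens), read by polymerase chain reaction, with a stated time of 1 h (on this read-out lower numbers stand for stronger inhibition and higher numbers for weaker inhibition), compound 1 gives 810 nM, the lowest of the two plain numbers. Compound 2, which carries a methyl on the fused ring in place of the phenyl, gives 5900 nM, a gap beyond the usual scatter. Compound 3 reaches only the limit of the assay, > 10000 nM. For the measured compounds named here, the one step measured directly, an at least 1.6-fold higher number from compound 2 to compound 3 (0.22 log units; that floor lies within the scatter), adds a second methyl to the fused ring and sits at the limit of > 10000 nM in this assay, at which 1 of the 3 values shown sits, so its true size is not known.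

Compound 4 `Cc1[nH]n(-c2nc3cc(Br)ccc3[nH]2)c(=O)c1Cc1ccccc1` differs from compound 1 by bromo in place of phenyl on an aromatic carbon. Going by the values given here, no measured step touches that position with that pair of groups; the only change at the fused ring that is counted, from compound 2 to compound 3, concerns a methyl and is limited by the assay floor. The nearest guide is the contrast between compound 1 and compound 2, where losing the phenyl for a smaller group moved the number up beyond the scatter. For compound 4 a rise in this assay is therefore expected, smaller than that contrast; bromo is neither phenyl nor methyl and its effect is unmeasured here. The step is estimated as a 3.1-fold higher number from compound 1 to compound 4 (0.49 log units; beyond the scatter). Compound 4 is expected to give about 2500 nM, within 800 nM to 8000 nM.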

Compound 4, half-maximal inhibitory concentration: 490 nM
Compound 4: middle estimate off by 5.1-fold (0.71 log units), on the high side; the whole stated range lies above it.
By their numbers in this assay, from the lowest: compounds 4 and 1 (each within the scatter of the next); then compound 2. At a limit, above all of these: compound 3.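

The step in this assay is a 1.7-fold lower number from compound 1 to compound 4 (0.22 log units; within the scatter), so no difference between phenyl and bromo can be read at this position in this assay. Before compound 4, only compound 1 carried a group at this position, and nothing showed whether the six-membered aromatic ring was needed there; a single bromine now takes the place of its six carbons with the number staying within the scatter, which suggests that the phenyl ring is not required here, at least in this pair. Nothing measured on these compounds bears on why phenyl and bromo read alike.

Open, as far as these compounds go, is whether this position tolerates groups of other kinds, such as an amine, a carboxylic acid or a longer chain, and whether plain hydrogen there would read like phenyl and bromo or show that a group at this position matters at all. From the compounds shown here alone, compound 3 gives > 10000 nM, which is a limit, so the true size of the step from adding its second methyl also stays open.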